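This account rests on a few compounds, and the source may have more. Where it says the series, first, only, none or still open, it means among the compounds named here.

Series notes. Among the measured compounds shown here, the shared core of compound 1 `CCOC(=O)CCC(=O)N1CCN(CCCOc2cc3c(Nc4ccc(F)c(Cl)c4)ncnc3cc2OC)CC1` carries a saturated chain closed by an ester, and the three measured members differ only in how far that chain runs. In a functional assay on A549 cells (Homo sapiens) for cytotoxicity, read by MTT assay, with a stated time of 24 h, tested at 40 uM (on this read-out lower numbers stand for a stronger effect and higher numbers for a weaker effect at the one concentration tested), compound 1 gives 67.4%, the second highest of the three numbers. Compound 2 `CCCCCCOC(=O)CCC(=O)N1CCN(CCCOc2cc3c(Nc4ccc(F)c(Cl)c4)ncnc3cc2OC)CC1` gives 74.2%; the step of a number 6.8 percentage points higher from compound 1 to compound 2 (within the scatter) lies within the scatter. Compound 3 `CCCCCCCCCOC(=O)CCC(=O)N1CCN(CCCOc2cc3c(Nc4ccc(F)c(Cl)c4)ncnc3cc2OC)CC1` gives 17.9%; the step of a number 49.5 percentage points lower from compound 1 to compound 3 (beyond the scatter) and the step of a number 56.3 percentage points lower from compound 2 to compound 3 (beyond the scatter) are both large and beyond the scatter.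

Compound 4 `CCCCCCCCCCCOC(=O)CCC(=O)N1CCN(CCCOc2cc3c(Nc4ccc(F)c(Cl)c4)ncnc3cc2OC)CC1` is not yet measured. It differs from compound 1 by nonyl in place of hydrogen on a saturated chain carbon, two bonds along the chain from an oxygen next to a carbonyl group. For the measured compounds named here, the steps that bear on it are the ones that grow the same chain: a number 6.8 percentage points higher from compound 1 to compound 2 (within the scatter) showed nothing beyond the scatter, whereas a number 49.5 percentage points lower from compound 1 to compound 3 (beyond the scatter) and a number 56.3 percentage points lower from compound 2 to compound 3 (beyond the scatter) showed large falls. Compound 4 carries the chain further than compound 3, so on these three compounds a value near compound 3 or lower is expected, with no ground to expect a return toward compound 1. The expected step is a number 47.4 percentage points lower from compound 1 to compound 4 (beyond the scatter). Compound 4 is therefore estimated at 20%, between 5% and 45%.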

Compound 4, a percentage reported as activity, at one concentration (the size of the read-out at that concentration, not a potency): 12%
Estimate against measurement, compound 4: 8 percentage points above; the measured number falls inside the stated range.
By their numbers in this assay, from the lowest: compounds 4 and 3 (each within the scatter of the next); then compounds 1 and 2 (each within the scatter of the next).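

Working notes on the chain. With nonyl at this place, the low level reached with heptyl holds in this assay: a number 5.9 percentage points lower from compound 3 to compound 4 (within the scatter), so the two long-chain members cannot be ordered and the low number is not confined to one chain length. Among the compounds shown here, the distance to the short-chain members also stays large, with a number 55.4 percentage points lower from compound 1 to compound 4 (beyond the scatter) and a number 62.2 percentage points lower from compound 2 to compound 4 (beyond the scatter), so the four compounds fall into two groups, with no member going against that split: hydrogen and butyl at this place on one side, heptyl and nonyl on the other. No measured evidence here accounts for this split in the numbers.

As far as these compounds go, it remains open where between butyl and heptyl the change sets in, and whether a longer chain than nonyl stays at this low level or turns back toward the short-chain numbers. From the compounds shown here alone, it also remains open whether the same split holds when the ester is replaced by an amide or a carboxylic acid, or at concentrations other than the one tested, since these numbers show only a stronger or weaker effect at that one concentration.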